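The compounds below may be only part of what the source reports. "The series", "measured", "known", "first", "only" and "open" are said of these compounds alone.

Among the measured compounds shown here, in a functional assay on MDA-MB-435 cells (Homo sapiens) for antiproliferative activity, read by sulforhodamine B assay, with a stated time of 48 h (a higher number here means a weaker inhibitor, a lower number a stronger inhibitor), compound 1 `O=C(NCCCNc1cc(-c2cn(-c3ccccc3)nc2-c2cccc(O)c2)ccn1)Nc1ccc(F)cc1` gives 1660 nM and holds the lower of the two numbers so far, while compound 2 `O=C(NCCCNc1cc(-c2cn(-c3ccccc3)nc2-c2cccc(O)c2)ccn1)Nc1cccc(C(F)(F)F)c1` gives 3410 nM and holds the higher. Compound 3 `COc1cccc(-c2nn(-c3ccccc3)cc2-c2ccnc(NCCCNC(=O)Nc3ccc(F)cc3)c2)c1` differs from compound 1 by methyl in place of hydrogen on an oxygen on an aromatic ring in the change 3-hydroxyphenyl to 3-methoxyphenyl. For the measured compounds named here, the one measured step of a 2.1-fold higher number from compound 1 to compound 2 (0.31 log units; beyond the scatter) is modest and lies elsewhere, on an amide-type nitrogen, so it sets a scale only. Going by the values given here, no measured step touches this oxygen, yet a modest rise in the number in this assay is expected. The expected step is a 1.8-fold higher number from compound 1 to compound 3 (0.26 log units; within the scatter) as a working estimate. Compound 3 is estimated at 3000 nM within an expected range of 1000 nM to 9000 nM for now.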

Compound 3, half-maximal inhibitory concentration: 5610 nM
Compound 3: middle estimate off by 1.9-fold (0.27 log units), on the low side, within the range that was stated.
By their numbers in this assay, from the lowest: compound 1; then compounds 2 and 3 (each within the scatter of the next).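

Methyl in place of hydrogen on the oxygen gives the first measured step at this position: in this assay the change from 3-hydroxyphenyl to 3-methoxyphenyl reads as a 3.4-fold higher number from compound 1 to compound 3 (0.53 log units; beyond the scatter) and is modest, so the number is sensitive to this oxygen and the free hydroxy gives the lower number of this pair. A single step sets no trend. No evidence available here bears on the reason for this rise. Going by these compounds, it remains open whether ethoxy or an amine on this aromatic ring would stay near compound 1, and whether the same methyl change reads alike with 3-(trifluoromethyl)phenyl on the amide-type nitrogen.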